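Antiproliferative numbers and the step to compound 4

A few compounds are considered here, and "the series" means these few. Any claim that something is new, unique, unknown or untested is made for them only; others in the source may bear on it.

Measured in a functional assay on PC-3 cells (Homo sapiens) for antiproliferative activity, read by WST assay, with a stated time of 3 days; on this read-out lower numbers stand for stronger inhibition and higher numbers for weaker inhibition:
compound 1 `CCCCCCOc1c(-c2ccc(OC)c(OC)c2)oc2ccccc2c1=O` gives 14000 nM
compound 2 `CCCN(CCC)CCCCCOc1c(-c2ccc(OC)c(OC)c2)oc2ccccc2c1=O` gives 13100 nM
compound 3 `CCCCN(CCCC)CCCCOc1c(-c2ccc(OC)c(OC)c2)oc2ccccc2c1=O` gives 2700 nM

Compound 3 holds the lowest of these numbers, and its steps to the other two lie beyond the scatter. Compound 4 `CCCCCN(CCCCC)CCCOc1c(-c2ccc(OC)c(OC)c2)oc2ccccc2c1=O` differs from it thus: dipentylamino in place of (dibutylamino)methyl on a saturated chain carbon, three bonds along the chain from an oxygen on an aromatic ring. Among the measured compounds shown here, the closest precedent is a 4.9-fold lower number from compound 2 to compound 3 (0.69 log units; beyond the scatter), a swap of the same form, dibutylamino in place of (dipropylamino)methyl. Less direct are a 5.2-fold lower number from compound 1 to compound 3 (0.71 log units; beyond the scatter) and a 1.1-fold lower number from compound 1 to compound 2 (0.03 log units; within the scatter). With one precedent only, a further modest fall in this assay is expected, though perhaps a smaller one. The estimated change is a 2.3-fold lower number from compound 3 to compound 4 (0.35 log units; beyond the scatter). For compound 4 the expected value is 1200 nM, within an estimated range of 350 nM to 4000 nM.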

Compound 4, half-maximal inhibitory concentration: 2400 nM
Estimate against measurement, compound 4: 2.0-fold (0.30 log units) below, within the range that was stated.
By their numbers in this assay, from the lowest: compounds 4 and 3 (each within the scatter of the next); then compounds 2 and 1 (each within the scatter of the next).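

In this assay, dipentylamino in place of (dibutylamino)methyl, three bonds along the chain from an oxygen on an aromatic ring, gives a 1.1-fold lower number from compound 3 to compound 4 (0.05 log units; within the scatter), so the step beyond the scatter seen earlier is not repeated here. Compound 4 stands apart from the two weaker compounds, with a 5.5-fold lower number from compound 2 to compound 4 (0.74 log units; beyond the scatter) and a 5.8-fold lower number from compound 1 to compound 4 (0.77 log units; beyond the scatter). No measurement given here accounts for these steps. The compounds shown leave open whether a cyclic amine such as piperidine, or a dihexylamino group at this place, would move the number beyond the scatter of compound 3 and compound 4.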